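Diaryl urea series: trifluoromethyl to chloro swap

A few compounds are considered here, and "the series" means these few. Any claim that something is new, unique, unknown or untested is made for them only; others in the source may bear on it.

Measured so far:
compound 1 `COc1cc2cc(Oc3ccc(NC(=O)Nc4cccc(C(F)(F)F)c4)cc3)c(C)nc2cc1OC` — 2870 nM
compound 2 `COc1cc2cc(Oc3ccc(NC(=O)Nc4ccc(Cl)c(C(F)(F)F)c4)cc3)c(C)nc2cc1OC` — 1940 nM

In a functional assay on SK-MEL-2 cells (Homo sapiens) for inhibition, read by sulforhodamine B assay, with a stated time of 48 h (a lower number here means a stronger inhibitor of growth, a higher number a weaker inhibitor of growth), compound 2 gives 1940 nM. Going by the values given here, the only other number comes from compound 1, which gives 2870 nM, and the step of a 1.5-fold lower number from compound 1 to compound 2 (0.17 log units; within the scatter) lies within the scatter, so the two compounds are not separated by this assay.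

Compound 3 `COc1cc2cc(Oc3ccc(NC(=O)Nc4ccc(Cl)c(Cl)c4)cc3)c(C)nc2cc1OC` differs from compound 2 by chloro in place of trifluoromethyl on an aromatic carbon. Among the compounds with values here, no measured step replaces a trifluoromethyl with a chloro, so nothing bears on this change directly. Within the data shown here, the one step available, a 1.5-fold lower number from compound 1 to compound 2 (0.17 log units; within the scatter), concerns the chloro group that stays in place in compound 3 and was itself within the scatter; the substituent pattern on this ring has so far moved the read-out little. Among the measured compounds shown here, with no measured precedent for the swap itself, the expectation for compound 3 is a step of a 1.3-fold higher number from compound 2 to compound 3 (0.11 log units; within the scatter) that stays within the scatter, in either direction. Compound 3 is therefore estimated at 2500 nM in this assay, with a range from 1000 nM to 6500 nM.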

Compound 3, concentration for total growth inhibition: 6550 nM
Compound 3: the middle estimate sits 2.6-fold (0.42 log units) below what was measured, outside the stated range (above it).
By their numbers in this assay, from the lowest: compounds 2 and 1 (each within the scatter of the next); then compound 3.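

In this assay, the group meta to a large group on this ring now has a measurable effect: trifluoromethyl and chloro are not interchangeable here, and a 3.4-fold higher number from compound 2 to compound 3 (0.53 log units; beyond the scatter) is a step beyond the scatter, unlike the earlier chloro addition on the same ring. The comparison with the compound lacking the ring chloro points the same way, with a 2.3-fold higher number from compound 1 to compound 3 (0.36 log units; beyond the scatter), but that step changes two places on the ring and cannot separate their contributions. Going by these compounds alone, the only single-place reading of this position is therefore the exchange of trifluoromethyl for chloro, and nothing available explains the size of that step.

The compounds shown leave open whether the higher number follows from chloro itself or would also appear with other groups at this position, such as methyl, methoxy, a nitrile or an amine. They also leave open whether the same exchange would give a step of similar size if the neighbouring chloro were replaced by hydrogen, a combination that would isolate trifluoromethyl against chloro on a simpler ring.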